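The source may report more compounds than this note shows. Statements on the series, on what has been measured and on what is new or still open speak of the compounds shown alone.

Compound 3 `O=[N+]([O-])c1ccc(-c2nc3cc(C(F)(F)F)ccc3[nH]2)cc1` is the starting point here, and its cell tolerance is measured in an ADME assay on Vero cells (Chlorocebus sabaeus) for cytotoxicity; a higher number here means that more compound is tolerated, a lower number that less compound is tolerated. In this test compound 3 gives 45000 nM, the higher of the two exact numbers available. Compound 2 `COc1ccc(-c2nc3cc(C(F)(F)F)ccc3[nH]2)c([N+](=O)[O-])c1` gives 20000 nM, a lower number by a gap beyond the usual scatter. Compound 1 `O=[N+]([O-])c1ccc(-c2nc3ccccc3[nH]2)c([N+](=O)[O-])c1` gives > 100000 nM, which is a limit and not a number.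

Compound 4 `O=[N+]([O-])c1ccc(-c2nc3cc(C(F)(F)F)ccc3[nH]2)c([N+](=O)[O-])c1` differs from compound 3 by a single change, nitro in place of hydrogen on an aromatic carbon. Going by the values given here, no pair of measured compounds shows this change alone, so any forecast is rough. The nearest guide is compound 1, which carries the same pair of nitro groups as compound 4. Compound 1 sits at the limit > 100000 nM. A small upward step in this assay is therefore expected, probably no larger than the scatter. The expected change is a 1.2-fold higher number from compound 3 to compound 4 (0.09 log units; within the scatter). For compound 4 the estimated value is 55000 nM, with an expected range from 20000 nM to 120000 nM.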

Compound 4, half-maximal cytotoxic concentration: 25000 nM
The estimate for compound 4 lay 2.2-fold (0.34 log units) above the measured number; low and high end bracket the measured number.
By their numbers in this assay, from the lowest: compounds 2, 4 and 3 (each within the scatter of the next, the first and the last beyond it). At a limit, above all of these: compound 1.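

In this assay neither nitro step moves the number clearly: nitro in place of hydrogen on this aromatic carbon, ortho to a large group, gives a 1.8-fold lower number from compound 3 to compound 4 (0.26 log units; within the scatter) and nitro in place of methoxy gives a 1.3-fold higher number from compound 2 to compound 4 (0.10 log units; within the scatter). Among the steps leading to compound 4, the one that stands out is trifluoromethyl in place of hydrogen, which gives an at least 4.0-fold lower number from compound 1 to compound 4 (0.60 log units; beyond the scatter) as the only step here beyond the scatter. Going by these compounds, its full size stays unknown because compound 1 stands at a limit of the assay and not at a number: the limit of > 100000 nM in this assay, at which 1 of the 4 values shown sits.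

The compounds shown leave open whether an amine or a carboxylic acid in place of this nitro would shift the number beyond the scatter. They also leave open whether a methyl or a chlorine in place of the trifluoromethyl would give a similar step.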